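A few compounds are considered here, and "the series" means these few. Any claim that something is new, unique, unknown or untested is made for them only; others in the source may bear on it.

Compound 3 `N#Cc1cnc(NCc2cnccc2C(F)(F)F)cc1NC1CCOCC1` gives 900 nM in an assay on isolated protein for inhibition of protein kinase C theta type (Homo sapiens), read by TR-FRET, with a stated time of 2 h (on this read-out higher numbers stand for weaker inhibition and lower numbers for stronger inhibition), the highest number among the three measured compounds. Compound 1 `N#Cc1cnc(NCc2cnccc2C(F)(F)F)cc1N[C@H]1CC[C@H](O)CC1` gives 350 nM in this assay, and compound 2 `N#Cc1cnc(NCc2cnccc2C(F)(F)F)cc1NC[C@H]1CC[C@H](O)CC1` gives 50 nM. The change to compound 4 `CC1(C)[C@@H](C(N)=O)C[C@H]1Nc1cc(NCc2cnccc2C(F)(F)F)ncc1C#N` is 3-carbamoyl-2,2-dimethylcyclobutyl in place of oxan-4-yl on a nitrogen on an aromatic ring. Going by the values given here, two measured steps touch the same nitrogen on an aromatic ring: a 2.6-fold higher number from compound 1 to compound 3 (0.41 log units; beyond the scatter) and an 18-fold higher number from compound 2 to compound 3 (1.26 log units; beyond the scatter), each moving to a higher number when the group with one hydrogen-bond donor was replaced by oxan-4-yl, which has none. Among the compounds with values here, since the entering group again carries one hydrogen-bond donor, the step of a 4.5-fold lower number from compound 3 to compound 4 (0.65 log units; beyond the scatter) is expected to run toward a lower number, though no measured step tells how a four-membered ring of carbon only behaves here. Compound 4 is estimated at 200 nM, within 50 nM to 800 nM.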

Compound 4, half-maximal inhibitory concentration: 1.4 nM
For compound 4 the middle estimate is 140-fold (2.15 log units) above the measured one; the whole stated range lies above it.
By their numbers in this assay, from the lowest: compound 4; then compound 2; then compound 1; then compound 3.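

At this nitrogen on an aromatic ring, 3-carbamoyl-2,2-dimethylcyclobutyl gives a lower number in this assay than every group seen before (a 640-fold lower number from compound 3 to compound 4 (2.81 log units; beyond the scatter)), (a 250-fold lower number from compound 1 to compound 4 (2.40 log units; beyond the scatter)) and (a 36-fold lower number from compound 2 to compound 4 (1.55 log units; beyond the scatter)). The position can therefore reach far stronger inhibition than the hydroxycyclohexyl groups showed, even compared with the best of them, in compound 2. No supporting data explain this gain.

On these data alone, the carbamoyl group, the two methyl groups and the four-membered ring all enter together, so their shares remain unknown. A cyclobutyl carrying a carboxylic acid, or lacking the two methyl groups, would help separate them.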